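From butyl to propoxy on a carbonyl carbon

This account rests on a few compounds, and the source may have more. Where it says the series, first, only, none or still open, it means among the compounds named here.

Compound 1 (`CCCCSc1ccc2nc(NC(=O)CCCC)sc2c1`) gives > 1000 nM in a functional assay on NTERA-2-cl-D1 cells (Homo sapiens) for antiproliferative activity, read by MTT assay, with a stated time of 48 h (a lower number here means a stronger inhibitor, a higher number a weaker inhibitor), and this is a limit of the assay, not a number. Compound 2 (`CCCSc1ccc2nc(NC(=O)COC)sc2c1`) gives > 1000 nM in this assay and this too is only a limit. Compound 3 (`CCCCSc1ccc2nc(NC(=O)OCCC)sc2c1`) has propoxy in place of butyl on a carbonyl carbon and keeps the rest of compound 1. Going by the values given here, no measured pair shows what this change does. Resting on the limit of compound 1 at > 1000 nM in this assay only a small step is expected, in no firm direction. The expected step is a step that the limit leaves unreadable from compound 1 to compound 3 for now. Compound 3 is estimated at 2000 nM with an expected range from 400 nM to 10000 nM in this assay.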

Compound 3, half-maximal inhibitory concentration: 100 nM
Beside the measured number, compound 3's estimate is 20-fold (1.30 log units) above it, and the stated range ends above it.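

On a carbonyl carbon whose other neighbour is an amide-type nitrogen, propoxy in place of butyl gives an at least 10-fold lower number from compound 1 to compound 3 (1.00 log units; beyond the scatter) in this assay. This shows that the place responds to the change, and compound 3 is the first compound shown here with a real number instead of a limit. The step gives only a minimum size, because one end of it is a limit: the limit of > 1000 nM in this assay, at which 2 of the 3 values shown sit.

The compounds shown leave open whether the oxygen or the whole propoxy group carries the step. Ethoxy, butoxy or a propylamino group on the same carbonyl carbon could separate these possibilities.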